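The source may hold more compounds than are shown below. What is called first, only, known or untested is meant among the compounds shown, and "the series" means these compounds.

Compound 1, `CCOC(=O)c1cnn(-c2nc(-c3ccccc3F)c(C#N)c(=O)n2C)c1N`, gives 86 ug/mL in a functional assay, with a stated time of 10 min; a lower number here means a stronger inhibitor, a higher number a weaker inhibitor.
Compound 2, `CCOC(=O)c1cnn(-c2nc(-c3ccccc3Cl)c(C#N)c(=O)n2C)c1N`, gives 98 ug/mL in this assay.
Compound 3, `Cn1c(NN)nc(-c2ccccc2Cl)c(C#N)c1=O`, gives 46 ug/mL in this assay.

Compounds 1 and 2 share one core and differ in a single place: fluoro in place of chloro on an aromatic carbon. That change made the step of a 1.1-fold lower number from compound 2 to compound 1 (0.06 log units; within the scatter), so the two numbers are not told apart by this measurement. Compound 3 carries a different core, and the difference between the two cores is not broken down here; its number is the lowest of the three, but its gap to compound 1 lies within the scatter, so no order between those two can be claimed.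

Compound 4, `Cn1c(NN)nc(-c2ccccc2F)c(C#N)c1=O`, is not yet measured. It differs from compound 3 by fluoro in place of chloro on an aromatic carbon, which is the same change that turns compound 2 into compound 1, made at the same kind of place. Because a 1.1-fold lower number from compound 2 to compound 1 (0.06 log units; within the scatter) stayed within the scatter, the step from compound 3 to compound 4 is expected to be small as well, about a 1.1-fold lower number from compound 3 to compound 4 (0.04 log units; within the scatter). Compound 4 is therefore estimated at 42 ug/mL in this assay, with a range from 25 ug/mL to 75 ug/mL.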

Compound 4, half-maximal inhibitory concentration: 49 ug/mL
Beside the measured number, compound 4's estimate is 1.2-fold (0.07 log units) below it, and the stated range covers the measured number.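

On the second core, fluoro in place of chloro gave a 1.1-fold higher number from compound 3 to compound 4 (0.03 log units; within the scatter) in this assay, so this measurement does not tell the two compounds apart. Set beside the earlier step, the change shows no measurable difference between the two cores: the same change on two cores in this assay, a 1.1-fold lower number (0.06 log units; within the scatter) from compound 2 to compound 1 and a 1.1-fold higher number (0.03 log units; within the scatter) from compound 3 to compound 4, 1.2-fold (0.08 log units) apart, within the scatter of two such steps. This shows that, for these two cores, the swap left the number within the scatter both times, but it does not show that the change has no effect at all, and two cores are too few to support a rule for the whole series.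

The compounds shown carry only chloro or fluoro at this place on the aromatic ring, so it remains open whether a plain hydrogen, a methyl, a methoxy or an amine there would shift the number on either core. Going by these compounds, it also remains open whether a step of that kind, if it went beyond the scatter, would carry from one core to the other.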